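The source may report more compounds than this note shows. Statements on the series, on what has been measured and on what is new or still open speak of the compounds shown alone.

Of the compounds shown here, three share one core and have been tested in an assay on microsomes from intestine for inhibition of acyl-CoA:cholesterol acyltransferase (Oryctolagus cuniculus); on this read-out lower numbers stand for stronger inhibition and higher numbers for weaker inhibition. Compound 1 `CC(C)c1cccc(C(C)C)c1OC(=O)NC(=O)OCc1ccccc1` gives 77 nM. Compound 2 `CCCCC(C)(C)OC(=O)NC(=O)Oc1c(C(C)C)cccc1C(C)C` gives 64 nM. Compound 3 `CC(C)c1cccc(C(C)C)c1OC(=O)NC(=O)SCc1ccc(Cl)cc1` gives 160 nM, the highest number of the three: the step of a 2.1-fold higher number from compound 1 to compound 3 (0.32 log units; beyond the scatter) and the step of a 2.5-fold higher number from compound 2 to compound 3 (0.40 log units; beyond the scatter) both lie beyond the scatter, while the step of a 1.2-fold lower number from compound 1 to compound 2 (0.08 log units; within the scatter) lies within it.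

Compound 4 `CC(C)c1cccc(C(C)C)c1OC(=O)NC(=O)SCCCc1ccccc1` differs from compound 3 in one place: phenethyl in place of 4-chlorophenyl on a saturated chain carbon bound to a sulfur. The sulfur atom and the carbonyl stay in place; only the tail beyond the sulfur changes. Within the data shown here, two measured steps bear on this, though neither matches it exactly. The step of a 1.2-fold lower number from compound 1 to compound 2 (0.08 log units; within the scatter) shows that swapping a ring-bearing tail for a chain tail on the oxygen side of the carbonyl changed little. The step of a 2.1-fold higher number from compound 1 to compound 3 (0.32 log units; beyond the scatter) shows that bringing in the sulfur together with the 4-chlorobenzyl tail raised the number modestly. Since compound 4 keeps the sulfur and alters only the tail, the expectation for this assay is a step of a 1.2-fold lower number from compound 3 to compound 4 (0.09 log units; within the scatter), small and not clearly beyond the scatter, with the number for compound 4 estimated at 130 nM, between 55 nM and 320 nM.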

Compound 4, half-maximal inhibitory concentration: 69 nM
Compound 4: middle estimate off by 1.9-fold (0.28 log units), on the high side; the range from low to high includes it.
By their numbers in this assay, from the lowest: compounds 2, 4 and 1 (each within the scatter of the next); then compound 3.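

With the sulfur and carbonyl held in place, the tail alone moves the result in this assay: replacing 4-chlorobenzyl with 3-phenylpropyl gives a 2.3-fold lower number from compound 3 to compound 4 (0.37 log units; beyond the scatter), a step beyond the scatter. The earlier step to compound 3 changed the sulfur and the tail together, whereas this one shows that the group on the saturated chain carbon bound to the sulfur can shift the number by itself, and that a sulfur-bearing compound need not sit apart from the oxygen-linked compounds: compound 3 now stands alone, while compound 4 falls within the scatter of its neighbours, compounds 1 and 2. Nothing measured here explains why this tail change has this effect.

Removing the chlorine and lengthening the chain happen in the same step, so the compounds shown cannot say how much each contributes; an unsubstituted benzyl or a 3-(4-chlorophenyl)propyl group on the sulfur would separate the two. Also open, as far as these compounds go, is how the number responds to a longer chain, such as 5-phenylpentyl, or to a tail with no ring at all on the sulfur, such as octyl.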